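Nitroxide-bearing amino acid derivatives and a protecting-group removal

A few compounds are considered here, and "the series" means these few. Any claim that something is new, unique, unknown or untested is made for them only; others in the source may bear on it.

The measured compounds are:
compound 1, `CC1(C)N(O)C(c2ccc(OCC(=O)NCCCC[C@H](N)C(=O)O)cc2)=[N+]([O-])C1(C)C`, 98800 nM
compound 2, `CC(C)(C)OC(=O)N[C@@H](CCCCNC(=O)COc1ccc(C2=[N+]([O-])C(C)(C)C(C)(C)N2O)cc1)C(=O)O`, 97700 nM
compound 3, `CC(C)(C)OC(=O)N[C@@H](CCC(=O)NCCOc1ccc(C2=[N+]([O-])C(C)(C)C(C)(C)N2O)cc1)C(=O)O`, 59000 nM

All three were tested in a functional assay on PC-12 cells (Rattus norvegicus) for inhibition, read by MTT assay; a lower number here means that less compound is needed, a higher number that more compound is needed for the effect. Compound 1 gives 98800 nM and compound 2 gives 97700 nM, the two sitting together within the usual scatter. Compound 3 gives 59000 nM, which is also within the scatter of both others, so no ordering among the three can be claimed.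

The change from compound 2 to compound 1 is hydrogen in place of tert-butoxycarbonyl on an amine nitrogen. The step that it made, a 1.0-fold higher number from compound 2 to compound 1 (0.00 log units; within the scatter), is within the scatter.

Compound 4, `CC1(C)N(O)C(c2ccc(OCCNC(=O)CC[C@H](N)C(=O)O)cc2)=[N+]([O-])C1(C)C`, has not yet been measured in this assay . It relates to compound 3 by hydrogen in place of tert-butoxycarbonyl on an amine nitrogen. The place of the change is the same for both pairs, so this is the same change as from compound 2 to compound 1. How the core of compound 3 differs from the core of compound 2 is not broken down here.

Because the step of a 1.0-fold higher number from compound 2 to compound 1 (0.00 log units; within the scatter) was flat, the same change is expected to leave compound 4 close to compound 3, with an expected step of a 1.0-fold lower number from compound 3 to compound 4 (0.01 log units; within the scatter). Compound 4 is therefore estimated at 58000 nM in this assay , with the range 25000 nM to 135000 nM reflecting the scatter of such measurements.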

Compound 4, half-maximal effective concentration: 58100 nM
Beside the measured number, compound 4's estimate is 1.0-fold (0.00 log units) below it, within the range that was stated.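

In this assay, putting hydrogen in place of tert-butoxycarbonyl on an amine nitrogen gives a 1.0-fold lower number from compound 3 to compound 4 (0.01 log units; within the scatter), so the removal of this protecting group again leaves the number flat. Set beside the earlier case, the change behaves alike on the two cores, and the series so far gives no sign that the core alters its outcome: the same change on two cores in this assay, a 1.0-fold higher number (0.00 log units; within the scatter) from compound 2 to compound 1 and a 1.0-fold lower number (0.01 log units; within the scatter) from compound 3 to compound 4, 1.0-fold (0.01 log units) apart, within the scatter of two such steps This shows only that the change made no readable difference on these two cores in this one cell assay; it does not show that the same would hold on a further core, and since neither step moves the number, it says nothing about how a change that did have an effect would carry over.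

The compounds shown leave open whether a different group on that amine nitrogen, such as an acetyl group or a benzyloxycarbonyl group, or a methyl ester in place of the carboxylic acid, would shift the number in this assay. They also leave open whether a longer chain between the amino acid part and the aromatic ring would make any difference, and whether the flat result extends to such compounds.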